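Swapping a dimethoxyphenyl for phenyl in a coumarin-linked dienone

The compounds below may be only part of what the source reports. "The series", "measured", "known", "first", "only" and "open" are said of these compounds alone.

Four compounds share one core, a dienone flanked by two aromatic rings, with a triazole-tethered coumarin hanging off one of them. Compound 1 `COc1ccc(/C=C/C(=O)/C=C/c2ccc(OCc3cn(CCCCCOc4cc(=O)oc5ccccc45)nn3)c(OC)c2)cc1OC` and compound 2 `COc1ccc(/C=C/C(=O)/C=C/c2ccc(OCc3cn(CCOc4cc(=O)oc5ccccc45)nn3)c(OC)c2)cc1OC` both carry a 3,4-dimethoxyphenyl at the far end of the dienone; the difference between the two cores is not broken down here. Among the measured compounds shown here, in a functional assay on COLO 205 cells (Homo sapiens) for inhibition, read by sulforhodamine B assay, with a stated time of 48 h, tested at 50 uM (on this read-out lower numbers stand for less inhibition of growth and higher numbers for more inhibition of growth at the one concentration tested), compound 1 gives 43% and compound 2 gives 80%, the highest of the three numbers measured so far.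

Compound 3 `COc1cc(/C=C/C(=O)/C=C/c2ccccc2)ccc1OCc1cn(CCCCCOc2cc(=O)oc3ccccc23)nn1` is compound 1 with one change, (phenyl in place of 3,4-dimethoxyphenyl on a double-bonded chain carbon bound to a double-bonded chain carbon). In this assay compound 3 gives 22%, and the step of a number 21 percentage points lower from compound 1 to compound 3 (beyond the scatter) lies beyond the scatter.

Compound 4 `COc1cc(/C=C/C(=O)/C=C/c2ccccc2)ccc1OCc1cn(CCOc2cc(=O)oc3ccccc23)nn1` is the still unmeasured partner of compound 2, made by the same change, (phenyl in place of 3,4-dimethoxyphenyl on a double-bonded chain carbon bound to a double-bonded chain carbon). Since this change was measured only once, on the pair with the longer tether, the expectation for compound 4 rests on carrying that single step over to the higher starting point of compound 2. The step from compound 2 to compound 4 is therefore expected to read a number 22 percentage points lower from compound 2 to compound 4 (beyond the scatter), close to the earlier one. On that basis compound 4 is estimated to give 58% in this assay, most likely between 42% and 74%.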

Compound 4, percent growth inhibition at one concentration: 54%
Compound 4: the middle estimate sits 4 percentage points above what was measured; the range from low to high includes it.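

In this assay, the change from 3,4-dimethoxyphenyl to phenyl gives a number 26 percentage points lower from compound 2 to compound 4 (beyond the scatter), so the number falls on the core of compound 2 as it did on the core of compound 1. For these two cores, the change carries over as a drop of similar size, even though the starting values differ: the same change on two cores in this assay, a number 21 percentage points lower (beyond the scatter) from compound 1 to compound 3 and a number 26 percentage points lower (beyond the scatter) from compound 2 to compound 4, 5 percentage points apart, within the scatter of two such steps

Among the compounds shown here, this agreement rests on only two pairs, read in one assay at one concentration, so it does not show why phenyl gives the lower number or whether a similar drop would appear on any other core.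

The compounds shown leave open which part of the 3,4-dimethoxyphenyl group matters. The methoxy groups leave together, and no ring with a single methoxy group, a hydroxyl group or a fluorine appears among them. They also leave open how the same change would behave with a longer chain in the tether, or with an amine built into that chain.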